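The compounds below may be only part of what the source reports. "The series", "measured", "known", "first", "only" and "open" are said of these compounds alone.

Compound 1 `COc1cc(OC)c2c(=O)cc(-c3ccc(OCCN)cc3)oc2c1` and compound 2 `COc1cc(OC)c2c(=O)cc(-c3ccc(OCC(O)CN(C)C)cc3)oc2c1` share the same core and differ only in the chain bound through an oxygen on an aromatic ring. In a functional assay (Homo sapiens) for antiproliferative activity, read by resazurin assay, with a stated time of 48 h, tested at 10 uM (a higher number here means a stronger effect of the compound at the concentration tested, a lower number a weaker effect), compound 1 gives 35%, and compound 2 gives 60%, the higher of the two numbers measured; the step between them is a number 25 percentage points higher from compound 1 to compound 2 (beyond the scatter).

Compound 3 `COc1cc(OC)c2c(=O)cc(-c3ccc(NCCN4CCCC4)cc3)oc2c1` swaps the whole chain: (2-(pyrrolidin-1-yl)ethyl)amino in place of 3-(dimethylamino)-2-hydroxypropoxy on an aromatic carbon. For the measured compounds named here, only one measured step exists, and it altered the chain at a different place while keeping the oxygen link, so it bears only loosely on this swap; it does show that reshaping this chain can move the read-out by a modest amount in either direction. The estimated step is therefore a number 5 percentage points lower from compound 2 to compound 3 (within the scatter), small and inside the scatter, but with a wide range of uncertainty. Compound 3 is expected to give about 55%, somewhere between 30% and 78%.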

Compound 3, a percentage reported as inhibition, at one concentration (the size of the read-out at that concentration, not a potency): 51%
The estimate for compound 3 lay 4 percentage points above the measured number; measured number inside the range.
By their numbers in this assay, from the lowest: compound 1; then compounds 3 and 2 (each within the scatter of the next).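

Replacing 3-(dimethylamino)-2-hydroxypropoxy with (2-(pyrrolidin-1-yl)ethyl)amino gives a number 9 percentage points lower from compound 2 to compound 3 (within the scatter) in this assay, so on this aromatic carbon the two chains cannot be told apart, although the entering chain has no oxygen and carries a five-membered non-aromatic ring. Against 2-aminoethoxy, the same chain gives a number 16 percentage points higher from compound 1 to compound 3 (beyond the scatter), which leaves compound 1 the lowest of the three, beyond the scatter of both others. No available evidence explains why these chains read as they do.

On these data alone, in compound 3 the link atom and the rest of the chain differ together, so what the nitrogen link does alone stays open. Also open, as far as these compounds go, is whether a piperidine or morpholine ring in place of the pyrrolidine, or a longer chain, would keep the read-out at this level.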